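The source may hold more compounds than are shown below. What is called first, only, known or untested is meant among the compounds shown, and "the series" means these compounds.

Measured so far in a functional assay on OVCAR-5 cells (Homo sapiens) for inhibition, read by CCK-8 assay, with a stated time of 72 h, tested at 1 uM; a lower number here means less inhibition of growth, a higher number more inhibition of growth at the concentration tested:
- compound 1, `CN(C)C(=O)c1cc2cnc(Nc3ccc(NC(=O)C4(C(=O)Nc5ccc(Cl)cc5)CC4)cc3)nc2n1C1CCCC1`: 8.1%
- compound 2, `CN(C)C(=O)c1cc2cnc(Nc3ccc(NC(=O)C4(C(=O)Nc5cccc(F)c5)CC4)cc3)nc2n1C1CCCC1`: 26.3%
- compound 3, `CN(C)C(=O)c1cc2cnc(Nc3ccc(NC(=O)C4(C(=O)Nc5cccc(O)c5)CC4)cc3)nc2n1C1CCCC1`: 58.5%

Compound 1 stands lowest of the three numbers. Its nearest neighbour is compound 2, reached by a number 18.2 percentage points higher from compound 1 to compound 2 (beyond the scatter), a modest step beyond the scatter. The furthest is compound 3, reached by a number 50.4 percentage points higher from compound 1 to compound 3 (beyond the scatter), a large step. Between the two higher compounds the step is a number 32.2 percentage points higher from compound 2 to compound 3 (beyond the scatter).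

The next compound, compound 4, `CN(C)C(=O)c1cc2cnc(Nc3ccc(NC(=O)C4(C(=O)Nc5ccccc5)CC4)cc3)nc2n1C1CCCC1`, is unmeasured. Its difference from compound 1 is hydrogen in place of chloro on an aromatic carbon. The change sits on the six-membered aromatic ring of carbon only, para to a large group, and reads at one bond further out as 4-chlorophenyl to phenyl.

Both measured steps that start from compound 1 replace the 4-chlorophenyl and both raise growth inhibition in this assay: the modest one to compound 2 and the large one to compound 3. Neither of them is a simple loss of chloro, so they bear on the present step only loosely. On this basis a modest rise beyond the scatter is expected for compound 4, giving a number 11.9 percentage points higher from compound 1 to compound 4 (beyond the scatter) as the estimated step. Compound 4 is therefore estimated at 20% in this assay, within 5% to 40%.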

Compound 4, percent growth inhibition at one concentration: 52.1%
The estimate for compound 4 lay 32.1 percentage points below the measured number, and the stated range ends below it.
By their numbers in this assay, from the lowest: compound 1; then compound 2; then compounds 4 and 3 (each within the scatter of the next).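

In this assay the low reading goes with the chloro itself: with hydrogen in its place on the aromatic carbon para to a large group, the series shows a number 44 percentage points higher from compound 1 to compound 4 (beyond the scatter), so the rise from compound 1 needs no new substituent at all. The plain phenyl also separates from the 3-fluorophenyl, with a number 25.8 percentage points higher from compound 2 to compound 4 (beyond the scatter), whereas the hydroxy gives no such separation, with a number 6.4 percentage points lower from compound 3 to compound 4 (within the scatter), so the high reading of compound 3 is matched by the unsubstituted ring and cannot be credited to the hydroxy. No data at hand give a reason for any of these steps.

Within the data shown here, open is whether a methoxy, an amine or a carboxylic acid on this ring would hold the level of compound 4 or fall away as the chloro does, and whether a chloro on another carbon of the ring would cost as much as the one in compound 1. From the compounds shown here alone, all readings come from a single concentration, so how compounds 3 and 4 compare at other concentrations also remains open.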